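The source may hold more compounds than are shown below. What is called first, only, known or untested is meant among the compounds shown, and "the series" means these compounds.

Of the compounds shown here, three have been measured so far: compound 1 `COc1cccc(Nc2nccc(-c3cc(C)oc3C)n2)c1`, compound 2 `Fc1cccc(Nc2nccc(-c3ccccn3)n2)c1` and compound 3 `COc1ccc(Nc2nccc(-c3ccccn3)n2)cc1`. In a functional assay for inhibition, with Homo sapiens as the target (on this read-out lower numbers stand for stronger inhibition and higher numbers for weaker inhibition), compound 1 gives 5800 nM, compound 2 gives 1000 nM and compound 3 gives 8300 nM. Compound 2 thus stands lowest of the three numbers, and its gaps to both compound 1 and compound 3 lie beyond the usual scatter of repeated measurements, so within this small set compound 2 is the most potent.

Compound 4 `Cc1cccc(Nc2nccc(-c3ccccn3)n2)c1` has not yet been measured. It differs from compound 2 in a single place: methyl in place of fluoro on an aromatic carbon, in words methyl in place of fluoro on an aromatic carbon, at a position meta to a large group. Among the measured compounds shown here, no measured pair shows this exact exchange, so no step can be read off from the data. The exchange is small, and a step of modest size is expected, quite possibly none beyond the scatter, in either direction. In this assay compound 4 is therefore expected to give about 1500 nM, with a plausible range from 500 nM to 4500 nM. The expected step is a 1.5-fold higher number from compound 2 to compound 4 (0.18 log units; within the scatter).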

Compound 4, half-maximal inhibitory concentration: 700 nM
Beside the measured number, compound 4's estimate is 2.1-fold (0.33 log units) above it; low and high end bracket the measured number.
By their numbers in this assay, from the lowest: compounds 4 and 2 (each within the scatter of the next); then compounds 1 and 3 (each within the scatter of the next).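

Swapping fluoro for methyl in this assay gives a 1.4-fold lower number from compound 2 to compound 4 (0.15 log units; within the scatter), so the two compounds cannot be told apart in this assay. Among the compounds shown here, this is the first direct reading at this position, on the carbon-only six-membered aromatic ring and meta to a large group: with the rest of the molecule unchanged, either fluoro or methyl can sit there with no readable difference in inhibition. No measurement at hand bears on why the two groups give matching results.

On these data alone, only these two groups can be compared at this position, so what an amine, a carboxylic acid or a longer chain would do there remains open. As far as these compounds go, it also remains open whether fluoro and methyl would match in the same way on the core of compound 1.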